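The source may hold more compounds than are shown below. What is called first, only, known or untested is meant among the compounds shown, and "the series" means these compounds.

Compound 1 `CC(=O)Oc1ccn2ncc(/C=N/N(C)S(=O)(=O)c3cc([N+](=O)[O-])ccc3C)c2c1` stands at the edge of what the assay reports: in an assay on isolated protein for inhibition of phosphatidylinositol 4,5-bisphosphate 3-kinase catalytic subunit beta isoform (Homo sapiens), read by 33P incorporation, with a stated time of 60 min (a higher number here means a weaker inhibitor, a lower number a stronger inhibitor), compound 1 gives > 1000 nM, which is a limit and not a number. Compound 2 `Cc1ccc([N+](=O)[O-])cc1S(=O)(=O)N(C)/N=C/c1cnn2cc(Br)ccc12` likewise gives only a limit in this assay, > 1000 nM. Compound 3 `Cc1ccc2c(/C=N/N(C)S(=O)(=O)c3cc([N+](=O)[O-])ccc3C)cnn2c1` gives > 1000 nM in this assay, again a limit. The step that the two limits leave unreadable from compound 2 to compound 3 is therefore unreadable, as every value sits at the same limit (the limit of > 1000 nM in this assay, at which 3 of the 3 values shown sit). Compound 4 `Cc1ccc([N+](=O)[O-])cc1S(=O)(=O)N(C)/N=C/c1cnn2ccc(C3CC3)cc12` differs from compound 1 by cyclopropyl in place of acetoxy on an aromatic carbon. Among the compounds with values here, no measured step bears on this change, since the measured series holds only limits. The expectation for compound 4 is therefore weak inhibition in this assay, with the step that the limit leaves unreadable from compound 1 to compound 4 expected to remain unreadable. Compound 4 is estimated at 3000 nM, in the range 700 nM to 20000 nM.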

Compound 4, half-maximal inhibitory concentration: > 1000 nM
Compound 4: a limit, no number; the forecaster's own chance of this, stated with the estimate: 70%; the middle value is on the limit's open side.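

Compound 4 gives > 1000 nM in this assay, a limit and not a number, so no step from compound 1 to compound 4 can be read: the limit of > 1000 nM in this assay, at which 4 of the 4 values shown sit.

The compounds shown leave open whether any change on the shared core gives a measurable value.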